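Swapping a Piperazine Tail for a Dimethylamino Tail

The source may hold more compounds than are shown below. What is called first, only, known or untested is meant among the compounds shown, and "the series" means these compounds.

Compound 2 `CN1CCN(CCCCCOC(=O)Nc2cccc(Cn3nc(-n4ccc5ccc(F)cc54)ccc3=O)c2)CC1` is known in a functional assay on EBC-1 cells (Homo sapiens) for inhibition, read by sulforhodamine B assay, with a stated time of 72 h (on this read-out higher numbers stand for weaker inhibition and lower numbers for stronger inhibition), only as a limit, <= 1000 nM. Compound 1 `CN(C)CCCCOC(=O)Nc1cccc(Cn2nc(Nc3ccccc3)ccc2=O)c1` differs from compound 2 in two places; in this assay compound 1 is likewise known only as a limit, > 10000 nM. Compound 3 `CN(C)CCCCOC(=O)Nc1cccc(Cn2nc(-n3ccc4ccc(F)cc43)ccc2=O)c1` differs from compound 2 by dimethylamino in place of (4-methylpiperazin-1-yl)methyl on a saturated chain carbon, four bonds along the chain from an oxygen next to a carbonyl group. For the measured compounds named here, no measured pair isolates this change, so the step from compound 2 to compound 3 is expected to be a step that the limit leaves unreadable from compound 2 to compound 3, not beyond the usual scatter in either direction. Compound 3 is therefore estimated to give 600 nM, within a range from 120 nM to 3000 nM.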

Compound 3, half-maximal inhibitory concentration: <= 1000 nM
Compound 3 ended at the assay's limit (the forecaster's own chance of this, stated with the estimate: 40%); the middle value lies beyond the limit too.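

In this assay, dimethylamino in place of (4-methylpiperazin-1-yl)methyl leaves compound 3 at the same limit as compound 2, so the size of this step cannot be read: the limit of <= 1000 nM in this assay, at which 2 of the 3 values shown sit. With the dimethylamino tail shared, 6-fluoro-1H-indol-1-yl in place of anilino on an aromatic carbon gives an at least 10-fold lower number from compound 1 to compound 3 (1.00 log units; beyond the scatter) in this assay, so this tail does not rule out activity at the limit reached by compound 2.

On these data alone, the true values of compound 2 and compound 3 remain open, and so does any real difference between their tails. As far as these compounds go, whether a morpholine or a longer chain would keep that level also remains open.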